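Replacing (methylamino)methyl with vinyl: an expectation

The compounds below may be only part of what the source reports. "The series", "measured", "known", "first", "only" and "open" are said of these compounds alone.

This account follows compound 1 `CNCc1ccc2c(c1)nc(Cn1c(=O)n(C(C)C)c3ccccc31)n2CCC(C)C` and its relatives in an ADME assay on HEp-2 cells (Homo sapiens) for cytotoxicity; on this read-out higher numbers stand for lower toxicity in this test and lower numbers for higher toxicity in this test. In this assay compound 1 gives 1480 nM. Compound 3 `C=C(C)n1c(=O)n(Cc2nc3cc(C#N)ccc3n2CCC(C)C)c2ccccc21` gives 1480 nM in this assay, which at the digits shown is level with compound 1 and within the scatter, so no order can be claimed between these two. Compound 2 `CC(C)CCn1c(Cn2c(=O)n(C(C)C)c3ccccc32)nc2ccc(C#N)cc21` gives 10000 nM in this assay, a higher number than compound 1 and beyond the scatter. Compound 1 and compound 3 together stand lowest of the three numbers.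

Compound 4 `C=Cc1ccc2c(c1)nc(Cn1c(=O)n(C(C)C)c3ccccc31)n2CCC(C)C` has not yet been measured. It differs from compound 1 by vinyl in place of (methylamino)methyl on an aromatic carbon. Among the measured compounds shown here, no step between two measured compounds mirrors this change, so the expectation rests loosely on the spread seen among compounds 1, 2 and 3. For compound 4 the step of a 1.7-fold higher number from compound 1 to compound 4 (0.23 log units; within the scatter) is expected to be small, towards a higher number, and possibly not beyond the scatter. Compound 4 is therefore estimated at 2500 nM, with a range from 800 nM to 8000 nM.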

Compound 4, half-maximal cytotoxic concentration: 6520 nM
Compound 4: the middle estimate sits 2.6-fold (0.42 log units) below what was measured; measured number inside the range.
By their numbers in this assay, from the lowest: compounds 1 and 3 (each within the scatter of the next); then compounds 4 and 2 (each within the scatter of the next).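

In this assay, among the compounds shown here, vinyl in place of (methylamino)methyl on this aromatic carbon gives a 4.4-fold higher number from compound 1 to compound 4 (0.64 log units; beyond the scatter), the first step at this position that can be read from a single change, and it runs towards lower toxicity in this test. The group that leaves carries a hydrogen-bond donor and acceptor while vinyl carries neither, yet this one step cannot tie the shift to either feature. Nothing measured here says why the number moves.

The compounds shown leave open whether the step follows the loss of the amine or the arrival of the vinyl group. An ethyl group or a (dimethylamino)methyl group on the same aromatic carbon would bear on that question, as a longer chain would on whether size matters here.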